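The source may hold more compounds than are shown below. What is called first, only, known or untested is meant among the compounds shown, and "the series" means these compounds.

In an ADME assay on microsomes from liver (Homo sapiens) for metabolic stability, read by LC-MS, with NADPH named in the record, with a stated time of 60 min, tested at 1 uM, in the absence of a further agent (a higher number here means that more of the compound is left, a lower number that less of the compound is left), compound 1 (`COc1ccc(-c2c(C)sc3c(N4CC[C@@H](NC(C)=O)C4)nc(C)nc23)cc1OC`) gives > 95% as a limit and not a number. Compound 2 (`COc1cc(-c2c(C)nc3c(N4CC[C@@H](NC(C)=O)C4)cc(C)nn23)cc(OC)c1OC`) gives > 95% as a limit too. Compound 3 (`COc1ccc(-c2c(C)nc3c(N4CC[C@@H](NC(C)=O)C4)cc(C)nn23)cc1F`) gives > 95% as a limit as well. Compound 3 therefore shares the limit of > 95% in this assay, at which 3 of the 3 values shown sit, with the other two compounds, so the data show no difference among them.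

Compound 4 (`CC(=O)N[C@@H]1CCN(c2cc(C)nn3c(-c4ccc5cc[nH]c5c4)c(C)nc23)C1`) carries 1H-indol-6-yl in place of the 3-fluoro-4-methoxyphenyl of compound 3 on an aromatic carbon of a five-membered aromatic ring with 2 nitrogen. The counted change is 1H-indol-6-yl in place of 3-fluoro-4-methoxyphenyl on an aromatic carbon and the rest of the molecule stays the same.

Among the measured compounds shown here, no measured pair of compounds differs in only one place, so the size of this step cannot be read directly from the data. For the measured compounds named here, the entering group appears in none of the measured compounds, so a modest fall is expected, possibly no larger than the usual scatter. The estimated change is a number at least 7 percentage points lower from compound 3 to compound 4 (that floor lies within the scatter) in this assay and remains only an expectation. The estimate for compound 4 is 88%, with an expected range from 65% to 100% until the measurement is known.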

Compound 4, percent of the compound remaining: > 95%
Compound 4 gave a limit, no number; the forecaster's own chance of this, stated with the estimate: 45%; at least 7 percentage points between middle value and limit.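

No step can be read between compound 3 and compound 4, because both compounds stand at the same limit and not at a number: the limit of > 95% in this assay, at which 4 of the 4 values shown sit.

The compounds shown leave open whether these four differ from one another at all in this assay.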